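Swapping a sulfonyl for a sulfanyl group in growth inhibition

This account rests on a few compounds, and the source may have more. Where it says the series, first, only, none or still open, it means among the compounds named here.

Measured in a functional assay on DU-145 cells (Homo sapiens) for inhibition, read by trypan blue exclusion, with a stated time of 96 h; a higher number here means a weaker inhibitor of growth, a lower number a stronger inhibitor of growth:
- compound 1 `O=C(/C(=C\c1ccccc1OCc1ccccc1)S(=O)(=O)Cc1ccc(F)cc1)c1ccc(Cl)cc1`: 10000 nM
- compound 2 `O=C(/C(=C\c1ccccc1OCc1ccccc1)S(=O)(=O)c1ccc(Br)cc1)c1ccc(Cl)cc1`: 1000 nM

Of the two measured compounds, compound 2 has the lower number, at 1000 nM, and so is the stronger inhibitor of growth. The next molecule is compound 3 `Cc1ccc(CS/C(=C/c2ccccc2OCc2ccccc2)C(=O)c2ccc(Cl)cc2)cc1`. It has (4-methylbenzyl)sulfanyl in place of (4-bromophenyl)sulfonyl on a double-bonded chain carbon bound to a carbonyl carbon and a double-bonded chain carbon.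

Within the data shown here, only one measured step bears on this change: a 10-fold lower number from compound 1 to compound 2 (1.00 log units; beyond the scatter). There, 4-bromophenyl took the place of 4-fluorobenzyl on a sulfonyl sulfur. Compound 3 again carries a benzyl group, as does compound 1 at 10000 nM, so a move towards a higher number in this assay is expected. Among the measured compounds shown here, no measured pair shows what replacing the sulfonyl with a sulfanyl does, so the size of the move remains uncertain. The expected step is a 5.0-fold higher number from compound 2 to compound 3 (0.70 log units; beyond the scatter). For compound 3 the estimated value is 5000 nM, with an expected range from 1000 nM to 20000 nM.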

Compound 3, concentration for 50% growth inhibition: 1000 nM
The estimate for compound 3 lay 5.0-fold (0.70 log units) above the measured number; low and high end bracket the measured number.
By their numbers in this assay, from the lowest: compounds 2 and 3 (each within the scatter of the next); then compound 1.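

In this assay, the step of no change at the digits printed from compound 2 to compound 3 (within the scatter) shows that this position can hold (4-methylbenzyl)sulfanyl in place of (4-bromophenyl)sulfonyl with no difference beyond the scatter, so a sulfonyl is not needed here to reach this level of growth inhibition. The step of a 10-fold lower number from compound 1 to compound 3 (1.00 log units; beyond the scatter) also shows that a benzyl group at this position does not by itself go with the high number of compound 1, although that step combines a change at the sulfur with a change from fluorine to methyl on the ring. No measurement given here explains these results.

The compounds shown leave open how much of that last step comes from the sulfur and how much from the ring substituent, a question that a direct comparison of (4-fluorobenzyl)sulfanyl with (4-fluorobenzyl)sulfonyl would help to settle. They also leave open how growth inhibition responds when this position carries a group of a different kind, such as an amine, a carboxylic acid or a longer chain ending in a benzene ring.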